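Oxetan-3-yl gives way to cyclopropylmethyl

The source may hold more compounds than are shown below. What is called first, only, known or untested is meant among the compounds shown, and "the series" means these compounds.

In an ADME assay on cells (Hepatocyte, Rattus norvegicus) for pharmacokinetics, read by LC-MS, with a stated time of 90 min, tested at 1 uM (a lower number here means slower removal, a higher number faster removal of the compound), compound 3 (`Nc1nc(-c2nn(Cc3ccccc3F)c3ncccc23)nc(N)c1NC(=O)OC1COC1`) gives 1.67 mL/min/kg, level with compound 2 (`COC(=O)Nc1c(N)nc(-c2nn(Cc3ccccc3F)c3ncccc23)nc1N`) at 1.67 mL/min/kg. Those two share the lowest number of the three, and compound 1 (`COC(=O)N(CCO)c1c(N)nc(-c2nn(Cc3ccccc3F)c3ncccc23)nc1N`) stands well apart at 61.7 mL/min/kg.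

Compound 4 (`Nc1nc(-c2nn(Cc3ccccc3F)c3ncccc23)nc(N)c1NC(=O)OCC1CC1`) has cyclopropylmethyl in place of oxetan-3-yl on an oxygen next to a carbonyl group.

Among the compounds with values here, the one measured change at this oxygen, oxetan-3-yl in place of methyl, shows no change at the digits printed from compound 2 to compound 3 (within the scatter), within the scatter. The large steps, a 37-fold lower number from compound 1 to compound 2 (1.57 log units; beyond the scatter) and a 37-fold lower number from compound 1 to compound 3 (1.57 log units; beyond the scatter), both remove the 2-hydroxyethyl group from the amide-type nitrogen, and compound 4 lacks that group too, so they do not bear directly on this change. Within the data shown here, no measured compound carries cyclopropylmethyl, so the upper side of the range is left wider.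

A small upward move, no larger than the scatter, is expected: a 1.5-fold higher number from compound 3 to compound 4 (0.18 log units; within the scatter). The estimate for compound 4 is 2.5 mL/min/kg, expected to fall between 1.4 mL/min/kg and 9 mL/min/kg.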

Compound 4, clearance: 23.3 mL/min/kg
Beside the measured number, compound 4's estimate is 9.3-fold (0.97 log units) below it; the whole stated range lies below it.
By their numbers in this assay, from the lowest: compounds 2 and 3 (each within the scatter of the next); then compound 4; then compound 1.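

The oxygen next to the carbonyl group now proves far from indifferent in this assay: cyclopropylmethyl in place of oxetan-3-yl gives a 14-fold higher number from compound 3 to compound 4 (1.14 log units; beyond the scatter) and, set against the methyl group, a 14-fold higher number from compound 2 to compound 4 (1.14 log units; beyond the scatter) even though oxetan-3-yl and cyclopropylmethyl have the same count of heavy atoms. The amide hydrogen alone does not hold the number at the level of compound 2 and compound 3: compound 4 has that hydrogen, yet the change from the 2-hydroxyethyl compound amounts only to a 2.6-fold lower number from compound 1 to compound 4 (0.42 log units; beyond the scatter) in this series. Nothing available explains the size of this step.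

The compounds shown leave open whether the ring oxygen or the added methylene link matters more. A cyclobutyl or an oxetan-3-ylmethyl group on this oxygen would separate the two.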